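Amide carbonyl substituent: 4-chlorophenyl to 1,3-oxazol-5-yl

This account rests on a few compounds, and the source may have more. Where it says the series, first, only, none or still open, it means among the compounds named here.

For the measured compounds named here, compound 2 `O=C(Nc1c(C(O)(C(F)(F)F)C(F)(F)F)ccc2ccccc12)c1ccc(Cl)cc1` and compound 1 `COCC(=O)Nc1c(C(O)(C(F)(F)F)C(F)(F)F)ccc2ccccc12` are the two measured members. Going by the values given here, in a functional assay (Sus scrofa) with sulfonylurea receptors; K-ATP channels (Homo sapiens) as the target (a lower number here means that less compound is needed, a higher number that more compound is needed for the effect), compound 2 gives 389 nM, and compound 1 gives 204 nM; the one known step, a 1.9-fold higher number from compound 1 to compound 2 (0.28 log units; within the scatter), leaves the two within the scatter of each other, so neither stands apart. Compound 3 `O=C(Nc1c(C(O)(C(F)(F)F)C(F)(F)F)ccc2ccccc12)c1cnco1` carries the change (1,3-oxazol-5-yl in place of 4-chlorophenyl on a carbonyl carbon). Among the compounds with values here, the only step that bears on this carbonyl substituent is a 1.9-fold higher number from compound 1 to compound 2 (0.28 log units; within the scatter); nothing measured covers 1,3-oxazol-5-yl. The expected step in this assay is therefore a 1.1-fold lower number from compound 2 to compound 3 (0.05 log units; within the scatter), none beyond the scatter. Compound 3 is estimated at 350 nM, with a range from 120 nM to 1000 nM.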

Compound 3, half-maximal effective concentration: 302 nM
Compound 3: the middle estimate sits 1.2-fold (0.06 log units) above what was measured; the measured number falls inside the stated range.
By their numbers in this assay, from the lowest: compounds 1, 3 and 2 (each within the scatter of the next).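

In this assay the carbonyl substituent now covers three groups without separating them: a 1.3-fold lower number from compound 2 to compound 3 (0.11 log units; within the scatter) and a 1.5-fold higher number from compound 1 to compound 3 (0.17 log units; within the scatter) are both printed as within the scatter. A five-membered aromatic ring with 2 hetero atoms on this carbonyl carbon therefore reads the same as 4-chlorophenyl and methoxymethyl in this assay. No evidence is available that explains this flat picture.

Open, on these data alone, is whether an amine, a carboxylic acid or a longer chain on this carbonyl carbon would give a step beyond the scatter.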